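A few compounds are considered here, and "the series" means these few. Any claim that something is new, unique, unknown or untested is made for them only; others in the source may bear on it.

Measured compounds in a functional assay on OVCAR-3 cells (Homo sapiens) for antiproliferative activity; a higher number here means a weaker inhibitor of growth, a lower number a stronger inhibitor of growth:
Compound 1 `Oc1cc(-c2ccc3ccccc3c2)nc2ncccc12` gives 8320 nM.
Compound 2 `Cc1cc(C)c2c(O)cc(-c3cccc4ccccc34)nc2n1` gives 347 nM.
Compound 3 `Cc1ccnc2nc(-c3ccc4ccccc4c3)cc(O)c12` gives 1290 nM.

Compound 2 stands lowest of the three in this assay, and its distance to compound 3 and to compound 1 lies beyond the scatter. How the core of compound 2 differs from the core of compound 3 is not broken down here. From compound 3 to compound 1 the change is hydrogen in place of methyl on an aromatic carbon, and it made a step of a 6.4-fold higher number from compound 3 to compound 1 (0.81 log units; beyond the scatter). Compound 4 `Cc1ccc2c(O)cc(-c3cccc4ccccc34)nc2n1` is not yet measured; it arises from compound 2 by hydrogen in place of methyl on an aromatic carbon, the same kind of change, though here the place is also meta to a methyl group (1 heavy atom). Compound 4 is expected to show a step of a 5.2-fold higher number from compound 2 to compound 4 (0.71 log units; beyond the scatter), resting on the step from compound 3 to compound 1 of a 6.4-fold higher number from compound 3 to compound 1 (0.81 log units; beyond the scatter). Compound 4 is therefore estimated at 1800 nM, between 700 nM and 5000 nM.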

Compound 4, concentration for 50% growth inhibition: < 10 nM
Compound 4 was reported as a limit; the forecaster's own chance of this, stated with the estimate: 2%; middle value at least 180-fold (2.25 log units) away from the limit.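

In this assay, hydrogen in place of methyl on an aromatic carbon gave a step of an at least 34-fold lower number from compound 2 to compound 4 (1.54 log units; beyond the scatter), so the change did not carry over from one core to the other, and its direction reversed: the same change on two cores in this assay, a 6.4-fold higher number (0.81 log units; beyond the scatter) from compound 3 to compound 1 and an at least 34-fold lower number (1.54 log units; beyond the scatter) from compound 2 to compound 4, at least 220-fold (2.34 log units) apart, beyond the scatter of two such steps. Going by these compounds, compound 4 gives < 10 nM, which is a limit of the assay and not a number, so the full size of its step stays unknown: the limit of < 10 nM in this assay, at which 1 of the 4 values shown sits. The two pairs show that the outcome of this change depends on the core, but not which difference between the cores decides it.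

On these data alone, it remains open how the change behaves on further cores. As far as these compounds go, it is also open whether ethyl, methoxy or an amine at this place would follow hydrogen or methyl.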